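The compounds below may be only part of what the source reports. "The series", "measured", "known", "first", "only" and "open" are said of these compounds alone.

In a functional assay on K562 cells (Homo sapiens) for cytotoxicity, read by MTT assay, with a stated time of 48 h (on this read-out higher numbers stand for weaker inhibition and lower numbers for stronger inhibition), compound 1 `CCOC(=O)/C=C/c1ccc2c(c1)C(=O)C(=O)N2Cc1ccc(OC)cc1` gives 10 nM, while compound 2 `COC(=O)/C=C/c1ccc2c(c1)N(Cc1ccc(OC)cc1)C(=O)C2=O` gives 4860 nM. Compound 1 therefore holds the lower of the two numbers, and the gap between them lies well beyond the usual scatter. The next compound to be tested, compound 3 `COc1ccc(CN2C(=O)C(=O)c3cc(/C=C/C(=O)OC(C)(C)C)ccc32)cc1`, departs from compound 1 at a single place: tert-butyl in place of ethyl on an oxygen next to a carbonyl group. The same difference can be read as ethoxycarbonyl to tert-butoxycarbonyl. Within the data shown here, no measured pair differing in one place is available, so the data give no direct measure of what such an exchange does in this assay. The expectation rests on two values: compound 1 at 10 nM sits at the low end of what has been seen, and compound 2 at 4860 nM shows how much higher a number can lie among these few compounds. A move toward a higher number, beyond the scatter, is therefore expected, and the estimated step is an 8.0-fold higher number from compound 1 to compound 3 (0.90 log units; beyond the scatter). For compound 3 the estimated value is 80 nM, with an expected range from 10 nM to 1000 nM.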

Compound 3, half-maximal inhibitory concentration: 50 nM
Compound 3: middle estimate off by 1.6-fold (0.20 log units), on the high side; low and high end bracket the measured number.
By their numbers in this assay, from the lowest: compound 1; then compound 3; then compound 2.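

In this assay, among these compounds, the exchange of ethyl for tert-butyl on an oxygen next to a carbonyl group now has a measured size, a 5.0-fold higher number from compound 1 to compound 3 (0.70 log units; beyond the scatter) and this is the first direct reading of any single change, since the earlier compounds offered no pair differing in one place. The step is beyond the scatter but modest, so the number does respond to the group on this oxygen, yet the change from 2 to 4 heavy atoms leaves compound 3 at 50 nM and does not abolish cytotoxicity in these cells. The data offer no measurement that would explain why this exchange raises the number.

Going by these compounds, one step cannot show whether the number follows the size of the group on this oxygen, so it remains open how an isopropyl group, a longer chain such as n-butyl or a benzyl group would fall relative to compound 1 and compound 3. On these data alone, it also remains open what the free carboxylic acid or a primary amide in place of the ester would give on the same core.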